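Benzoyl ring variation: from compound 2 to compound 3

The source may report more compounds than this note shows. Statements on the series, on what has been measured and on what is new or still open speak of the compounds shown alone.

Measured so far:
compound 1 `CC1(C)C=C(n2ccccc2=O)c2cc(C(=O)c3ccccc3)ccc2O1`: 6.61
compound 2 `CC1(C)C=C(n2ccccc2=O)c2cc(C(=O)c3ccc(O)cc3)ccc2O1`: 6.65

Both compounds were read in a functional assay (aorta) with Rattus norvegicus as the target; on this read-out lower numbers stand for lower potency and higher numbers for higher potency (the scale is a negative logarithm). Compound 1 gives 6.61 and compound 2 gives 6.65. Going by the values given here, the only measured step, a number 0.04 log units higher from compound 1 to compound 2 (within the scatter), lies within the scatter, so compound 2 and compound 1 cannot be separated on these numbers; compound 2 stands with the higher of the two values, but the gap means nothing.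

Compound 3 `CC1(C)C=C(n2ccccc2=O)c2cc(C(=O)c3ccccc3F)ccc2O1` is not yet measured. The change from compound 2 is 2-fluorophenyl in place of 4-hydroxyphenyl on a carbonyl carbon.

Among the compounds with values here, the one measured step bears on it only loosely: it shows that exchanging hydrogen for hydroxy on the benzoyl ring, a number 0.04 log units higher from compound 1 to compound 2 (within the scatter), left the value unchanged within the scatter. Nothing measured here concerns fluorine or a change at the position now altered, so no direction can be read from the series. The working expectation is therefore a step of a number 0.05 log units lower from compound 2 to compound 3 (within the scatter), that is, none beyond the scatter.

Compound 3 is estimated at 6.6, with a range from 6.1 to 7.1.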

Compound 3, logarithm of the reciprocal of the active concentration, log(1/C): 7.08
Beside the measured number, compound 3's estimate is 0.48 log units below it; the measured number falls inside the stated range.
By their numbers in this assay, from the lowest: compounds 1 and 2 (each within the scatter of the next); then compound 3.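

In this assay, the step of a number 0.47 log units higher from compound 1 to compound 3 (beyond the scatter) for fluoro in place of hydrogen on an aromatic carbon, together with the step of a number 0.43 log units higher from compound 2 to compound 3 (beyond the scatter) for 2-fluorophenyl in place of 4-hydroxyphenyl on a carbonyl carbon, shows that this aromatic ring can respond to substitution. The earlier hydroxy exchange could not show this, as its step lay within the scatter, whereas compound 3 now stands highest of the three, with both of its steps beyond the scatter. Nothing available accounts for the gain, so the data give no explanation for the difference between the 2-fluorophenyl and 4-hydroxyphenyl compounds.

The compounds shown do not separate the identity of the substituent from its place on the ring: 3-fluorophenyl and 4-fluorophenyl would test the place, while 2-chlorophenyl and 2-methoxyphenyl would test the group at the same place. Going by these compounds, how a ring carrying an amine or a carboxylic acid would read, and whether a second fluoro adds to the step, also remains open.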